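The compounds below may be only part of what the source reports. "The series", "measured", "known", "first", "only" and "open" are said of these compounds alone.

Working notes on the series. The compounds share one core and differ only in the substituent on the benzyl ring. In a functional assay on MCF7 cells (Homo sapiens) for inhibition, read by MTT assay, with a stated time of 5 days (on this read-out higher numbers stand for weaker inhibition and lower numbers for stronger inhibition), compound 1 `Cc1cc(Nc2nc(NCc3ccccc3F)nc3[nH]ncc23)n[nH]1` gives 2310 nM. In this assay compound 2 `Cc1cc(Nc2nc(NCc3ccc(F)cc3)nc3[nH]ncc23)n[nH]1` gives 970 nM. In this assay compound 3 `Cc1cc(Nc2nc(NCc3ccc(Br)cc3)nc3[nH]ncc23)n[nH]1` gives 5340 nM. Compound 3 thus stands highest of the three numbers in this assay: the nearest is compound 1, with a 2.3-fold higher number from compound 1 to compound 3 (0.36 log units; beyond the scatter), and the furthest is compound 2, with a 5.5-fold higher number from compound 2 to compound 3 (0.74 log units; beyond the scatter). Moving the fluoro around the ring gives a 2.4-fold lower number from compound 1 to compound 2 (0.38 log units; beyond the scatter).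

Compound 4 `Cc1cc(Nc2nc(NCc3ccc(C#N)cc3)nc3[nH]ncc23)n[nH]1` has not yet been measured in this assay. Relative to compound 3 the change is cyano in place of bromo on an aromatic carbon. Among the measured compounds shown here, the only measured step at this position is a 5.5-fold higher number from compound 2 to compound 3 (0.74 log units; beyond the scatter), which shows that the group on this carbon can move the number well beyond the scatter. For the measured compounds named here, no compound here carries cyano, so the direction and size of the step to compound 4 cannot be read off directly; the bromo analogue compound 3 sits at the top of the set, which leaves more room for the number to fall than to rise. Compound 4 is therefore expected to give a 2.1-fold lower number from compound 3 to compound 4 (0.33 log units; beyond the scatter) in this assay, an estimate of 2500 nM with a range from 800 nM to 8000 nM.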

Compound 4, half-maximal inhibitory concentration: 6060 nM
Compound 4: middle estimate off by 2.4-fold (0.38 log units), on the low side; the measured number falls inside the stated range.
By their numbers in this assay, from the lowest: compound 2; then compound 1; then compounds 3 and 4 (each within the scatter of the next).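

Cyano and bromo on this aromatic carbon cannot be told apart in this assay (a 1.1-fold higher number from compound 3 to compound 4 (0.05 log units; within the scatter)), even though cyano brings a triple bond and a hydrogen-bond acceptor that bromo lacks. Fluoro on the same carbon now stands apart from two different groups rather than one: the step to cyano (a 6.2-fold higher number from compound 2 to compound 4 (0.80 log units; beyond the scatter)) lies beyond the scatter and runs in the same direction as the step to bromo (a 5.5-fold higher number from compound 2 to compound 3 (0.74 log units; beyond the scatter)), and 4-cyanophenyl also reads above 2-fluorophenyl (a 2.6-fold higher number from compound 1 to compound 4 (0.42 log units; beyond the scatter)), so compound 2 holds the lowest number of the four, with compound 1 next. No measurement at hand bears on why cyano and bromo read alike or why fluoro reads lower.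

The compounds shown carry only fluoro, bromo and cyano on this carbon, and fluoro is a single example, so it remains open whether the lower number belongs to fluoro alone. Chloro, methoxy, an amine or a carboxylic acid on the same carbon would show whether any other group reaches or passes compound 2.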